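Swapping the Ring Pair on the Oxygen of Compound 3

A few compounds are considered here, and "the series" means these few. Any claim that something is new, unique, unknown or untested is made for them only; others in the source may bear on it.

Measured in a functional assay on NCI-N87 cells (Homo sapiens) for inhibition, read by CellTiter-Glo, with a stated time of 72 h; a higher number here means a weaker inhibitor, a lower number a stronger inhibitor:
- Compound 1 `C=C(F)C(=O)Nc1cc2c(Nc3ccc(Oc4cc5nncn5cn4)c(C)c3)ncnc2cc1OCC`: 6.56 nM
- Compound 2 `C=CC(=O)Nc1cc2c(Nc3ccc(Oc4cc5nncn5cn4)c(C)c3)ncnc2cc1OCC`: 51.9 nM
- Compound 3 `Cc1cc(Nc2ncnc3cc(O)c(NC(=O)/C=C/[C@H]4CCCN4C)cc23)ccc1Oc1cc2nccn2cn1`: 41.7 nM

Compound 3 lies within the scatter of compound 2, and both are clearly weaker than compound 1. Compound 4 `Cc1cc(Nc2ncnc3cc(O)c(NC(=O)/C=C/[C@H]4CCCN4C)cc23)ccc1Oc1ccn2cnnc2c1` differs from compound 3 by a group of 9 heavy atoms (6 carbon, 3 nitrogen; one five-membered aromatic ring with 3 hetero atoms, one six-membered aromatic ring with 1 hetero atom) in place of a group of 9 heavy atoms (6 carbon, 3 nitrogen; one five-membered aromatic ring with 2 hetero atoms, one six-membered aromatic ring with 2 hetero atoms), on an oxygen on an aromatic ring. The two have the same atoms, joined differently.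

Going by the values given here, the only measured step, hydrogen in place of fluoro, is a 7.9-fold higher number from compound 1 to compound 2 (0.90 log units; beyond the scatter). Among the compounds with values here, it concerns a different group, so no measured step covers this exchange. Within the data shown here, it shows only that one small change can matter here. With no evidence for a direction, no shift beyond the scatter is expected in this assay, and the estimated step is a 1.2-fold lower number from compound 3 to compound 4 (0.08 log units; within the scatter). Compound 4 is expected at 35 nM, within an estimated range of 12 nM to 100 nM.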

Compound 4, half-maximal inhibitory concentration: 32.9 nM
Compound 4: middle estimate off by 1.1-fold (0.03 log units), on the high side; the range from low to high includes it.
By their numbers in this assay, from the lowest: compound 1; then compounds 4, 3 and 2 (each within the scatter of the next).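

On this oxygen on an aromatic ring, one ring pair can give way to another built from the same atoms with little consequence: the exchange gives a 1.3-fold lower number from compound 3 to compound 4 (0.10 log units; within the scatter) in this assay and stays inside the scatter. Not every change of one group here moves the number, then, even when the hetero atoms are shifted between the two rings. No measured evidence accounts for this result.

Still open is how a single phenyl ring or a morpholine on this oxygen would read, since both ring pairs shown are fused.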